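A Vinyl Group Replaces Methoxy on the Shared Core

The source may hold more compounds than are shown below. What is called first, only, known or untested is meant among the compounds shown, and "the series" means these compounds.

Two compounds built on a shared core have been examined in a functional assay on MCF7 cells (Homo sapiens) for cytotoxicity, read by CCK-8 assay, with a stated time of 24 h; a lower number here means a stronger inhibitor, a higher number a weaker inhibitor. Compound 1, `C/C(=C\c1cc(-c2ccc(S(C)(=O)=O)cc2)cs1)C(N)=O`, gives > 50000 nM in this assay, which is a limit of the assay and not a number. Compound 2, `COc1ccc(-c2csc(/C=C(\C)C(N)=O)c2)cc1`, likewise gives > 50000 nM in this assay, again a limit rather than a measured number. The step between them, a step that the two limits leave unreadable from compound 1 to compound 2, cannot therefore be sized, and compound 2 stands only at the limit of > 50000 nM in this assay, at which 2 of the 2 values shown sit, with no further number to place it against.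

The change considered now leads to compound 3, `C=Cc1ccc(-c2csc(/C=C(\C)C(N)=O)c2)cc1`, through (vinyl in place of methoxy on an aromatic carbon). Among the compounds with values here, no measured step bears on this change: the only step between measured compounds has both ends at the limit and so offers no size and no direction. Nothing in the data connects a vinyl group to a methoxy group in this assay. With compound 2 known only as a limit, no step beyond the scatter can be expected in either direction. For compound 3 the expected step is a step that the limit leaves unreadable from compound 2 to compound 3. Compound 3 is therefore estimated at 60000 nM, with a range from 15000 nM to 250000 nM, and is most likely to be reported once more as a limit.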

Compound 3, half-maximal inhibitory concentration: > 50000 nM
Compound 3: no number, only a limit (the forecaster's own chance of this, stated with the estimate: 75%); the middle value is on the limit's open side.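

Compound 3 gives > 50000 nM in this assay, which is a limit and not a number, and the steps from compound 1 and compound 2 to compound 3 cannot be read. The three compounds stand together: the limit of > 50000 nM in this assay, at which 3 of the 3 values shown sit.

The compounds shown leave open whether any substituent in this place on the shared core would give a measurable value in this assay.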